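Replacing the Phenylethenyl Arm: Growth Inhibition Expected

The source may hold more compounds than are shown below. What is called first, only, known or untested is meant among the compounds shown, and "the series" means these compounds.

Compound 1 `Cc1cc(O)c(C2=NN(c3ccc(S(N)(=O)=O)cc3)C(c3ccccc3O)C2)cc1Cl`: 7340 nM
Compound 2 `Cc1cc(O)c(C2=NN(c3ccc(S(N)(=O)=O)cc3)C(/C=C/c3ccccc3)C2)cc1Cl`: 17400 nM

In a functional assay on Malme-3M cells (Homo sapiens) for antiproliferative activity, with a stated time of 48 h (on this read-out higher numbers stand for weaker inhibition of growth and lower numbers for stronger inhibition of growth), compound 2 stands at the highest of the two numbers; its nearest neighbour is compound 1, reached by the step of a 2.4-fold higher number from compound 1 to compound 2 (0.37 log units; beyond the scatter). Compound 3 `COc1ccc(C2CC(c3cc(Cl)c(C)cc3O)=NN2c2ccc(S(N)(=O)=O)cc2)cc1OC` differs from compound 2 by 3,4-dimethoxyphenyl in place of 2-phenylethenyl on a saturated ring carbon. Going by the values given here, only one measured step bears on this change, and it shows that trading the 2-phenylethenyl arm for an aromatic ring moved the number modestly downward. A similar modest fall is expected here, estimated as a 1.9-fold lower number from compound 2 to compound 3 (0.29 log units; within the scatter). Compound 3 is therefore expected at 9000 nM, within a range from 3500 nM to 25000 nM.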

Compound 3, concentration for total growth inhibition: 24600 nM
Beside the measured number, compound 3's estimate is 2.7-fold (0.44 log units) below it; the measured number falls inside the stated range.
By their numbers in this assay, from the lowest: compound 1; then compounds 2 and 3 (each within the scatter of the next).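

The step of a 1.4-fold higher number from compound 2 to compound 3 (0.15 log units; within the scatter) lies within the scatter, so an aromatic ring in place of the 2-phenylethenyl arm brings no clear gain at this saturated ring carbon. The lower number of compound 1 therefore does not extend to every aromatic ring here, as a 3.4-fold higher number from compound 1 to compound 3 (0.53 log units; beyond the scatter) lies beyond the scatter. Nothing available explains this difference between the 2-hydroxyphenyl and 3,4-dimethoxyphenyl groups.
Still open, from the compounds shown here alone, is how an unsubstituted phenyl ring would compare at this carbon. So is the effect of a ring bearing an amine or a carboxylic acid.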